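Removal of trifluoromethyl from the benzamide of compound 2

The compounds below may be only part of what the source reports. "The series", "measured", "known", "first", "only" and "open" are said of these compounds alone.

Compound 1 `O=C(Nc1cccc(-n2cc(-c3ccncc3)c(-c3ccc(Cl)c(O)c3)n2)c1)Nc1ccc(Cl)c(Cl)c1` and compound 2 `COc1cc(-c2nn(-c3cccc(NC(=O)c4cccc(C(F)(F)F)c4)c3)cc2-c2ccncc2)ccc1Cl` carry the same core and differ in the amide-linked part. In a functional assay on OVCAR-8 cells (Homo sapiens) for inhibition, read by sulforhodamine B assay, with a stated time of 48 h (on this read-out higher numbers stand for weaker inhibition of growth and lower numbers for stronger inhibition of growth), compound 1 gives 1210 nM and compound 2 gives 2000 nM. Compound 2 holds the highest of the two numbers, yet its gap to compound 1 lies within the scatter, so no order between them is read. Compound 3 `COc1cc(-c2nn(-c3cccc(NC(=O)c4ccccc4)c3)cc2-c2ccncc2)ccc1Cl` is not yet measured. It differs from compound 2 in one place: hydrogen in place of trifluoromethyl on an aromatic carbon. The trifluoromethyl leaves and hydrogen enters on an aromatic carbon of a six-membered aromatic ring of carbon only, meta to a large group. Among the measured compounds shown here, no measured pair shows this change, so no step can be read from the series. The expected step of a 1.4-fold higher number from compound 2 to compound 3 (0.15 log units; within the scatter) is small, at most slightly beyond the scatter, leaning toward a higher number. Compound 3 is estimated at 2800 nM in this assay, with a range from 1200 nM to 6500 nM.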

Compound 3, concentration for 50% growth inhibition: 995 nM
Compound 3: middle estimate off by 2.8-fold (0.45 log units), on the high side; the measured number lies below the stated range.
By their numbers in this assay, from the lowest: compounds 3, 1 and 2 (each within the scatter of the next).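

In this assay, among the compounds shown here, the change from 3-(trifluoromethyl)phenyl to phenyl gives a 2.0-fold lower number from compound 2 to compound 3 (0.30 log units; within the scatter), the first step that can be read at a single position. The trifluoromethyl on this aromatic carbon is thus not required to keep growth inhibition at the level of compound 2, as the read-out does not separate compound 3 from compound 2. No measured finding bears on this step, so it stays an observation without an assigned cause.

As far as these compounds go, whether an amine or a carboxylic acid on this same carbon would give a step beyond the scatter remains open. Also open, from the compounds shown here alone, is whether hydrogen in place of trifluoromethyl would give a similar step on a compound with a different amide-linked part or a different substituent on the shared core.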